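This account rests on a few compounds, and the source may have more. Where it says the series, first, only, none or still open, it means among the compounds named here.

In an ADME assay on HepG2 2.2.15 cells (Homo sapiens) for cytotoxicity (on this read-out higher numbers stand for lower toxicity in this test and lower numbers for higher toxicity in this test), compound 1 `O=C(O)CCCC(=O)OCCc1c(-c2ccccc2Cl)c2cc(Cl)ccc2[nH]c1=O` gives 110000 nM and compound 2 `CC(=O)OCC(=O)OCCc1c(-c2ccccc2Cl)c2cc(Cl)ccc2[nH]c1=O` gives 100000 nM in the same test. The record between these two shows a 1.1-fold lower number from compound 1 to compound 2 (0.04 log units; within the scatter) and so no real separation. Compound 3 `C/C=C/C(=O)OCCc1c(-c2ccccc2Cl)c2cc(Cl)ccc2[nH]c1=O` gives 30000 nM and stands lowest of the three numbers, reached by a 3.7-fold lower number from compound 1 to compound 3 (0.56 log units; beyond the scatter) and by a 3.3-fold lower number from compound 2 to compound 3 (0.52 log units; beyond the scatter) on the two routes to it.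

Compound 4 `C/C=C/C=C/C(=O)OCCc1c(-c2ccccc2Cl)c2cc(Cl)ccc2[nH]c1=O` keeps the shared core and alters only the chain on the ester carbonyl of compound 3. The change is prop-1-en-1-yl in place of methyl on a double-bonded chain carbon bound to a double-bonded chain carbon and it turns prop-1-en-1-yl into penta-1,3-dien-1-yl on that carbonyl carbon. Within the data shown here, no measured step makes this exact change, so the evidence is indirect. Among the measured compounds shown here, the closest guide is compound 3 itself, the only measured compound with a prop-1-en-1-yl there, whose value of 30000 nM sits modestly under the other two. Compound 4 retains that unsaturated start of the chain, so a number near compound 3 is expected, with at most a small further move downward and probably none beyond the scatter. The estimate amounts to an expected 1.5-fold lower number from compound 3 to compound 4 (0.18 log units; within the scatter) in this read-out. For compound 4 the estimated value in this assay is 20000 nM with an expected range from 8000 nM to 50000 nM for the measurement.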

Compound 4, half-maximal cytotoxic concentration: 440000 nM
Compound 4: middle estimate off by 22-fold (1.34 log units), on the low side, and the stated range ends below it.
By their numbers in this assay, from the lowest: compound 3; then compounds 2 and 1 (each within the scatter of the next); then compound 4.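

Lengthening prop-1-en-1-yl to penta-1,3-dien-1-yl on the ester carbonyl carbon does not leave the number near that of the shorter chain: in this assay the added prop-1-en-1-yl, in place of methyl on a double-bonded chain carbon bound to a double-bonded chain carbon, gives a 15-fold higher number from compound 3 to compound 4 (1.17 log units; beyond the scatter) and moves the series from its lowest number to its highest. The longer chain also stands clear of the two other esters, with a 4.4-fold higher number from compound 2 to compound 4 (0.64 log units; beyond the scatter) and with a 4.0-fold higher number from compound 1 to compound 4 (0.60 log units; beyond the scatter) on the two remaining routes, so an unsaturated start of the chain does not by itself set a low number in this test. Nothing measured here accounts for the size of this step.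

The compounds shown leave open whether the higher number goes with the greater chain length or with the second double bond, and a saturated pentyl chain on the same carbonyl carbon would separate the two. Also open, going by these compounds, is whether the number keeps rising with a still longer chain, or how it responds to an amine or a carboxylic acid at the end of the penta-1,3-dien-1-yl chain.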